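A side chain change on compound 3

A few compounds are considered here, and "the series" means these few. Any claim that something is new, unique, unknown or untested is made for them only; others in the source may bear on it.

Compound 1 `Cc1c(C)c2c(c(C)c1N)CC(C)(C)O2`: 760 nM
Compound 2 `Cc1c(C)c2c(c(N(C)C)c1N)CC(C)(C)O2`: 550 nM
Compound 3 `CC(C)=Cc1c(C)c(N)c(C)c2c1OC(C)(C)C2`: 300 nM

In a functional assay (microsomes, liver) with Rattus norvegicus as the target (on this read-out higher numbers stand for weaker inhibition and lower numbers for stronger inhibition), compound 3 gives 300 nM, within the scatter of compound 2 at 550 nM. Compound 4 `Cc1c(N)c(C)c2c(c1CC(C)C)OC(C)(C)C2` differs from compound 3 in one place: isobutyl in place of 2-methylprop-1-en-1-yl on an aromatic carbon. The closest evidence is a 2.5-fold lower number from compound 1 to compound 3 (0.40 log units; beyond the scatter), where 2-methylprop-1-en-1-yl replaced methyl. The dimethylamino change, a 1.4-fold lower number from compound 1 to compound 2 (0.14 log units; within the scatter), bears on it less directly. Among the compounds with values here, no measured step removes only the double bond, so no shift beyond the scatter is expected. The expected change is a 1.2-fold higher number from compound 3 to compound 4 (0.07 log units; within the scatter). Compound 4 is estimated at 350 nM, with an expected range from 150 nM to 800 nM.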

Compound 4, half-maximal inhibitory concentration: 140 nM
Estimate against measurement, compound 4: 2.5-fold (0.40 log units) above, and the stated range ends above it.
By their numbers in this assay, from the lowest: compound 4; then compounds 3, 2 and 1 (each within the scatter of the next, the first and the last beyond it).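

With a 2.1-fold lower number from compound 3 to compound 4 (0.33 log units; beyond the scatter), the double bond of the side chain matters at this aromatic carbon, even though 2-methylprop-1-en-1-yl and isobutyl hold the same count of carbons. Extending from the core of compound 1 adds to this, with a 5.4-fold lower number from compound 1 to compound 4 (0.73 log units; beyond the scatter), so the saturated branched chain goes further than the earlier compounds showed. Nothing measured here explains why the saturated chain gives the lower number. The compounds shown leave open how a longer chain, such as n-pentyl, or a cyclopropylmethyl group would read at this carbon.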